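Compound 3: 4-chlorophenyl in place of ethyl

A few compounds are considered here, and "the series" means these few. Any claim that something is new, unique, unknown or untested is made for them only; others in the source may bear on it.

Compound 2 (`CCNC(=O)NC1CC(C)(C)Oc2ccc(Cl)cc21`) gives > 100000 nM in a functional assay on U-373MG ATCC cells (Homo sapiens) for inhibition, read by MTT assay, with a stated time of 72 h; on this read-out lower numbers stand for stronger inhibition and higher numbers for weaker inhibition. That value is a limit of the assay and not a number, so compound 2 has no exact place in the series. In this assay compound 1 (`CC1(C)CC(NC(=O)Nc2ccccc2)c2cc(Cl)ccc2O1`) gives 68000 nM.

Compound 3 (`CC1(C)CC(NC(=O)Nc2ccc(Cl)cc2)c2cc(Cl)ccc2O1`), still unmeasured, differs from compound 2 by 4-chlorophenyl in place of ethyl on an amide-type nitrogen.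

For the measured compounds named here, the only measured step that bears on this change is an at least 1.4-fold higher number from compound 1 to compound 2 (0.16 log units; that floor lies within the scatter), with ethyl in place of phenyl on an amide-type nitrogen. On these data alone, it runs in the opposite direction and gives only a floor, so its true size remains open. Going by the values given here, no measured step isolates the chlorine of the entering group.

With an aromatic ring back on that nitrogen, a value near that of compound 1 at 68000 nM is the working expectation. The expected change is towards a lower number, given as an at least 2.5-fold lower number from compound 2 to compound 3 (0.39 log units; beyond the scatter). For compound 3 the estimate is 40000 nM, with an expected range of 14000 nM to 100000 nM.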

Compound 3, half-maximal inhibitory concentration: 19000 nM
The estimate for compound 3 lay 2.1-fold (0.32 log units) above the measured number; measured number inside the range.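

In this assay, 4-chlorophenyl in place of ethyl on the amide-type nitrogen gives an at least 5.2-fold lower number from compound 2 to compound 3 (0.72 log units; beyond the scatter), so this change now has a step beyond the scatter, whereas the earlier step at this position had only a floor within it. Chloro in place of hydrogen on an aromatic carbon gives a 3.6-fold lower number from compound 1 to compound 3 (0.55 log units; beyond the scatter), which shows that the number at this position depends on what the aromatic ring carries as well as on the ring being there. The value of compound 2, > 100000 nM, is a limit of the assay and not a number, and the true size of the step from it stays open: the limit of > 100000 nM in this assay, at which 1 of the 3 values shown sits.

The compounds shown leave open whether another group on that aromatic carbon, such as fluoro, methoxy or a carboxylic acid, would shift the number in the same direction as chloro. They also leave open how a longer chain such as hexyl, or a basic group such as a dimethylamine at the end of a chain, would read on the amide-type nitrogen.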